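A few compounds are considered here, and "the series" means these few. Any claim that something is new, unique, unknown or untested is made for them only; others in the source may bear on it.

In a functional assay on MCF7 cells (Homo sapiens) for antiproliferative activity, read by sulforhodamine B assay, with a stated time of 48 h (on this read-out lower numbers stand for stronger inhibition and higher numbers for weaker inhibition), compound 1 `COc1ccc(/C=C/C(=O)c2ccccc2-c2ccc(F)cc2)cc1OC` gives 240 nM. Compound 2 `COc1cc(/C=C/C(=O)c2ccccc2-c2ccc(F)cc2)ccc1O` differs from compound 1 by hydrogen in place of methyl on an oxygen on an aromatic ring. In this assay compound 2 gives 4000 nM. This step was a 17-fold higher number from compound 1 to compound 2 (1.22 log units; beyond the scatter). Compound 3 `COc1ccc(/C=C/C(=O)c2ccccc2-c2cccc(F)c2)cc1OC` has a different core, the difference being (3-fluorophenyl in place of 4-fluorophenyl on an aromatic carbon), and gives 1200 nM. That step was a 5.0-fold higher number from compound 1 to compound 3 (0.70 log units; beyond the scatter). Compound 4 `COc1ccc(/C=C/C(=O)c2ccccc2-c2cccc(F)c2)cc1O` has not yet been measured in this assay; it differs from compound 3 by hydrogen in place of methyl on an oxygen on an aromatic ring, and the place is described in the same words as for the earlier change, so it is the same change made on the core of compound 3. Going by the values given here, only one earlier example of this change exists. The number for compound 4 is expected to rise by about a 13-fold higher number from compound 3 to compound 4 (1.10 log units; beyond the scatter) because the earlier step of a 17-fold higher number from compound 1 to compound 2 (1.22 log units; beyond the scatter) was large. Compound 4 is therefore estimated at 15000 nM, most likely between 5000 nM and 45000 nM.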

Compound 4, half-maximal inhibitory concentration: 65 nM
The estimate for compound 4 lay 230-fold (2.36 log units) above the measured number, outside the stated range (below it).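

In this assay, methoxy to hydroxy did not carry over between the two cores: with 3-fluorophenyl on the core, the change gave an 18-fold lower number from compound 3 to compound 4 (1.27 log units; beyond the scatter). The direction of the change therefore reversed, and the two steps stand well apart: the same change on two cores in this assay, a 17-fold higher number (1.22 log units; beyond the scatter) from compound 1 to compound 2 and an 18-fold lower number (1.27 log units; beyond the scatter) from compound 3 to compound 4, 310-fold (2.49 log units) apart, beyond the scatter of two such steps. This does not show that the fluorine's place alone decides the outcome, for the structures show that the two steps turn different methoxy groups of the shared ring into hydroxy, so the two differences are not separated here.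

The compounds shown leave open what each fluorophenyl core does when the other methoxy group is changed. They also leave open whether ethyl or a longer chain on that oxygen, or an amine in place of the hydroxy, would follow either step.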